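Swapping Cyano for Phenyl: Expected Cytotoxicity of Compound 4

The compounds below may be only part of what the source reports. "The series", "measured", "known", "first", "only" and "open" are said of these compounds alone.

Compound 1 `N#CC1CC(=O)N(c2cnn3c2CN(C(=O)Nc2cc(F)c(F)c(F)c2)C(C2CC2)C3)C1` is the starting point, tested in a toxicity assay on HepG2 2.2.15 cells (Homo sapiens) for cytotoxicity, read by CellTiter-Glo; on this read-out lower numbers stand for higher toxicity in this test and higher numbers for lower toxicity in this test. In this assay compound 1 gives > 200000 nM, which is a limit of the assay rather than a measured number. Two relatives carry a different group at the same place on the shared core. Compound 2 `O=C1OC(c2ccccc2)CN1c1cnn2c1CN(C(=O)Nc1cc(F)c(F)c(F)c1)C(C1CC1)C2` gives 7410 nM in this assay, and compound 3 `O=C1CC(c2ccc(F)cc2)CN1c1cnn2c1CN(C(=O)Nc1cc(F)c(F)c(F)c1)C(C1CC1)C2` gives 32100 nM. Both steps away from compound 1 run toward a lower number, meaning stronger toxicity: an at least 26-fold lower number from compound 1 to compound 2 (1.43 log units; beyond the scatter) and an at least 6.2-fold lower number from compound 1 to compound 3 (0.79 log units; beyond the scatter).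

Compound 4 `O=C1CC(c2ccccc2)CN1c1cnn2c1CN(C(=O)Nc1cc(F)c(F)c(F)c1)C(C1CC1)C2` has not yet been measured. It differs from compound 1 by phenyl in place of cyano on a saturated ring carbon. The closest measured step is an at least 6.2-fold lower number from compound 1 to compound 3 (0.79 log units; beyond the scatter), where a 4-fluorophenyl entered at the same saturated ring carbon; the step of an at least 26-fold lower number from compound 1 to compound 2 (1.43 log units; beyond the scatter) also brought in a phenyl and likewise lowered the number. Since the only difference between the new change and the step to compound 3 is a single fluorine on the entering ring, a downward step of a similar size, beyond the scatter, is expected for compound 4, namely an at least 6.6-fold lower number from compound 1 to compound 4 (0.82 log units; beyond the scatter). Compound 4 is therefore estimated to give about 30000 nM in this assay, with a likely range from 8000 nM to 120000 nM.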

Compound 4, half-maximal cytotoxic concentration: 12800 nM
Compound 4: middle estimate off by 2.3-fold (0.37 log units), on the high side, and the stated range covers the measured number.
By their numbers in this assay, from the lowest: compounds 2 and 4 (each within the scatter of the next); then compound 3. At a limit, above all of these: compound 1.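

Placing phenyl instead of cyano on this saturated ring carbon gives an at least 15-fold lower number from compound 1 to compound 4 (1.19 log units; beyond the scatter) in this assay, so the fall in the number seen with compound 3 does not depend on having a fluorine on the entering ring. Compound 1 stands at a limit, so any step from it shows only a minimum size: the limit of > 200000 nM in this assay, at which 1 of the 4 values shown sits. The fluorine still has a modest effect of its own, as hydrogen in place of fluoro gives a 2.5-fold lower number from compound 3 to compound 4 (0.40 log units; beyond the scatter), whereas 2-oxo-4-phenylpyrrolidin-1-yl in place of 2-oxo-5-phenyl-1,3-oxazolidin-3-yl gives a 1.7-fold higher number from compound 2 to compound 4 (0.24 log units; within the scatter), which leaves these two phenyl-bearing groups indistinguishable in this test.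

As far as these compounds go, it remains open whether an amine, a carboxylic acid or a longer alkyl chain at this saturated ring carbon would also lower the number, or whether this fall belongs to an aromatic ring. From the compounds shown here alone, it is also open whether a chloro or methoxy group on the phenyl would shift the number in the same direction as fluoro, or the opposite one.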